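The source may report more compounds than this note shows. Statements on the series, on what has been measured and on what is new or still open speak of the compounds shown alone.

Measured so far:
compound 1 `CO[C@]1(C(=O)N2CC[C@](c3ccc(C(F)(C(F)(F)F)C(F)(F)F)cc3)(S(=O)(=O)c3ccc(F)cc3)C2)CC[C@H](C(=O)O)CC1`: 82%
compound 2 `O=C([C@H]1CC[C@H](c2nnn[nH]2)CC1)N1CC[C@](c2ccc(C(F)(C(F)(F)F)C(F)(F)F)cc2)(S(=O)(=O)c2ccc(F)cc2)C1`: 100%

In an ADME assay on microsomes from liver (Homo sapiens) for metabolic stability, with a stated time of 10 min (a lower number here means that less of the compound is left, a higher number that more of the compound is left), compound 2 gives 100%, the higher of the two numbers, and compound 1 gives 82%.

The next compound is compound 3 `O=C(N1CC[C@](c2ccc(C(F)(C(F)(F)F)C(F)(F)F)cc2)(S(=O)(=O)c2ccc(F)cc2)C1)C1(O)CCS(=O)(=O)CC1`, which keeps the shared core and the amide carbonyl. The change is 4-hydroxy-1,1-dioxothian-4-yl in place of 4-(1H-tetrazol-5-yl)cyclohexyl on a carbonyl carbon. In short, 4-hydroxy-1,1-dioxothian-4-yl stands in place of 4-(1H-tetrazol-5-yl)cyclohexyl on a carbonyl carbon.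

Among the measured compounds shown here, only one measured step bears on this, a number 18 percentage points higher from compound 1 to compound 2 (beyond the scatter). It is modest, and it concerns the same place on the molecule, so groups on this carbonyl carbon can move the read-out beyond the scatter. Neither measured compound carries the entering group, so the data give no direct evidence for it.

With compound 2 at 100%, the top of the scale, any real step in this assay can only go downward, and a modest drop is expected. The expected change is a number 12 percentage points lower from compound 2 to compound 3 (beyond the scatter). For compound 3 the estimated value is 88%, with an expected range of 70% to 100%.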

Compound 3, percent of the compound remaining: 100%
Compound 3: the middle estimate sits 12 percentage points below what was measured, within the range that was stated.
By their numbers in this assay, from the lowest: compound 1; then compounds 2 and 3 (each within the scatter of the next).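

In this assay, the place on a carbonyl carbon whose other neighbours are an amide-type nitrogen in a ring holds a second, quite different group with the read-out still at the top of the scale: no change at the digits printed from compound 2 to compound 3 (within the scatter). The 4-hydroxy-1,1-dioxothian-4-yl group carries neither the tetrazole nor the cyclohexyl ring, so a read-out at this level does not need either of them, and a number 18 percentage points higher from compound 1 to compound 3 (beyond the scatter), a step of the same size as a number 18 percentage points higher from compound 1 to compound 2 (beyond the scatter). Nothing among the data on these compounds accounts for this result.

As far as these compounds go, with compound 2 and compound 3 both at the top of the scale, this read-out cannot separate the two groups, and how they would compare if less of each compound were left stays open. Also open, from the compounds shown here alone, are whether a 4-aminocyclohexyl group on this carbonyl carbon would keep the read-out at this level, and what a 1,1-dioxothian-4-yl group without the hydroxyl would give.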